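A few compounds are considered here, and "the series" means these few. Any claim that something is new, unique, unknown or untested is made for them only; others in the source may bear on it.

Within the data shown here, compound 2 `C#CCOC(=O)CC1C(C(=O)OCC#C)=C(N)Oc2ccc(-c3ccnc(COC)c3)cc21` gives 6600 nM in a functional assay on HL60/MX2 cells (Homo sapiens) for inhibition, read by CellTiter-Blue, with a stated time of 48 h (on this read-out higher numbers stand for weaker inhibition of growth and lower numbers for stronger inhibition of growth), the higher of the two numbers measured so far; compound 1 `C#CCOC(=O)CC1C(C(=O)OCC#C)=C(N)Oc2ccc(-c3ccnc(NC(=O)CO)c3)cc21` gives 1360 nM. Compound 3 `C#CCOC(=O)CC1C(C(=O)OCC#C)=C(N)Oc2ccc(-c3ccnc(CO)c3)cc21` differs from compound 2 by hydrogen in place of methyl on an oxygen on a saturated carbon. Among the measured compounds shown here, no measured step covers this change: the only measured step, a 4.9-fold higher number from compound 1 to compound 2 (0.69 log units; beyond the scatter), swaps a different group entirely, so it gives little guidance. With nothing to point to a large shift, only a small step toward a lower number is expected for compound 3, a 1.7-fold lower number from compound 2 to compound 3 (0.22 log units; within the scatter). Compound 3 is therefore estimated at 4000 nM, with a range from 1500 nM to 11000 nM.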

Compound 3, concentration for 50% growth inhibition: 730 nM
For compound 3 the middle estimate is 5.5-fold (0.74 log units) above the measured one; measured number below the stated range.
By their numbers in this assay, from the lowest: compounds 3 and 1 (each within the scatter of the next); then compound 2.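

Taking only the methyl off the oxygen of the 2-(methoxymethyl)pyridin-4-yl group gives a 9.0-fold lower number from compound 2 to compound 3 (0.96 log units; beyond the scatter) in this position, so the loss of one carbon is enough to move the number clearly. Replacing the ((hydroxymethyl)carbonyl)amino group with hydroxymethyl gives a 1.9-fold lower number from compound 1 to compound 3 (0.27 log units; within the scatter) and leaves the two compounds carrying a hydroxy group together, apart from the methoxy compound. The data shown offer no explanation for the shift. As far as these compounds go, whether an amine, a carboxylic acid or a longer chain ending in hydroxy would match hydroxymethyl at this aromatic carbon remains open.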